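Fluoro to hydrogen: from compound 2 to compound 4

This account rests on a few compounds, and the source may have more. Where it says the series, first, only, none or still open, it means among the compounds named here.

Of the compounds shown here, three have been measured so far. In an ADME assay on microsomes from liver (Rattus norvegicus) for metabolic stability, with a stated time of 30 min, tested at 1 uM (on this read-out higher numbers stand for a more stable compound and lower numbers for a less stable compound), compound 1 `CC[C@@H]1C(=O)N(C)c2cnc(-n3ccnc3-c3ccccc3)nc2N1C1CCCC1` gives 0%, compound 2 `CC[C@@H]1C(=O)N(C)c2cnc(-n3ccnc3-c3ccc(F)cc3)nc2N1[C@H]1CCOC1` gives 67% and compound 3 `CC(C)N1c2nc(-n3ccnc3-c3ccc(F)cc3)ncc2N(C)C(=O)C1(C)C` gives 10%. Compound 2 thus stands highest of the three, with compound 3 nearest and compound 1 furthest, both gaps well beyond the scatter.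

Compound 4 `CC[C@@H]1C(=O)N(C)c2cnc(-n3ccnc3-c3ccccc3)nc2N1[C@H]1CCOC1` differs from compound 2 in one place: hydrogen in place of fluoro on an aromatic carbon. Going by the values given here, no measured pair shows this change on its own. Compound 1 also carries phenyl and gives 0%, but it differs from compound 2 elsewhere as well, so the two changes cannot be separated. A downward step of moderate size is expected in this assay, as a number 22 percentage points lower from compound 2 to compound 4 (beyond the scatter). Compound 4 is estimated at 45%, within a range of 15% to 75%.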

Compound 4, percent of the compound remaining: 13%
The estimate for compound 4 lay 32 percentage points above the measured number; the measured number lies below the stated range.
By their numbers in this assay, from the lowest: compounds 1, 3 and 4 (each within the scatter of the next, the first and the last beyond it); then compound 2.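

Read alone in this assay, the change from 4-fluorophenyl to phenyl gives a number 54 percentage points lower from compound 2 to compound 4 (beyond the scatter) on this aromatic carbon, so the high number of compound 2 does not persist without the fluoro. With phenyl held constant, oxolan-3-yl in place of cyclopentyl gives only a number 13 percentage points higher from compound 1 to compound 4 (beyond the scatter) in the same assay, a smaller step than the loss of fluoro. Nothing available explains either step.

Still open, from the compounds shown here alone, is whether chloro or methoxy on this carbon would retain the number of compound 2. Also open, going by these compounds, is how cyclopentyl behaves alongside 4-fluorophenyl.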